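The compounds below may be only part of what the source reports. "The series", "measured", "known", "first", "only" and "open" are said of these compounds alone.

Measured so far:
- compound 1, `Cc1nc(Nc2ccc3sc(C(=O)Nc4c(C)cccc4Cl)cc3c2)cc(N2CCCCC2)n1`: 20.6%
- compound 2, `COc1cc2c(Nc3ccc4sc(C(=O)Nc5c(C)cccc5Cl)cc4c3)ncnc2cc1OCCCN1CCCCC1C`: 80.3%

Among the measured compounds shown here, in a functional assay on U-937 cells (Homo sapiens) for inhibition, read by MTT assay and WST assay, with a stated time of 72 h, tested at 10 uM (a lower number here means less inhibition of growth, a higher number more inhibition of growth at the concentration tested), compound 2 gives 80.3%, the higher of the two numbers; the only neighbour, compound 1, lies far lower, beyond the usual scatter. Compound 3, `COc1cc2c(Nc3ccc4sc(C(=O)Nc5c(C)cccc5Cl)cc4c3)ncnc2cc1OCCCN1CCCCC1`, differs from compound 2 by hydrogen in place of methyl on a saturated ring carbon, the group going from 2-methylpiperidin-1-yl to piperidin-1-yl. For the measured compounds named here, no measured pair shows this change. The shared core with compound 2 is kept, so compound 3 is expected to stay close to compound 2, with a step from compound 2 to compound 3 in this assay of a number 4.3 percentage points lower from compound 2 to compound 3 (within the scatter), within the scatter. For compound 3 the estimate is 76%, between 58% and 90%.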

Compound 3, percent growth inhibition at one concentration: 75.7%
Compound 3: the middle estimate sits 0.3 percentage points above what was measured, within the range that was stated.
By their numbers in this assay, from the lowest: compound 1; then compounds 3 and 2 (each within the scatter of the next).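

In this assay, the methyl on the saturated ring carbon, next to the ring nitrogen, can now be read as a single change: hydrogen in its place gives a step of a number 4.6 percentage points lower from compound 2 to compound 3 (within the scatter) and nothing more. At this position, then, 2-methylpiperidin-1-yl and piperidin-1-yl are not told apart at the concentration tested. No measurement available bears on a cause for this.

Open, as far as these compounds go, is whether a larger group on this ring carbon, such as ethyl or hydroxymethyl, would keep the number. Also open, from the compounds shown here alone, is what morpholin-4-yl in place of piperidin-1-yl would give.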